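Methoxy for Methylsulfanyl: Compound 3 to Compound 4

The source may hold more compounds than are shown below. What is called first, only, known or untested is meant among the compounds shown, and "the series" means these compounds.

Compound 1 `C=CCc1cc(-c2cccc([N+](=O)[O-])c2)ccc1O`: > 100000 nM
Compound 2 `C=CCc1cc(-c2cccc(C(F)(F)F)c2)ccc1O`: 65900 nM
Compound 3 `C=CCc1cc(-c2cccc(SC)c2)ccc1O`: > 100000 nM

In a functional assay on Lewis lung carcinoma cells (Mus musculus) for antiproliferative activity, read by MTT assay, with a stated time of 24 h (a lower number here means a stronger inhibitor, a higher number a weaker inhibitor), compound 3 stands at the limit of the assay, not at a number. Compound 1 also sits at that limit (the limit of > 100000 nM in this assay, at which 2 of the 3 values shown sit). Compound 2 alone gives a number, so the step of an at least 1.5-fold higher number from compound 2 to compound 3 (0.18 log units; that floor lies within the scatter) carries a direction but, with its floor inside the scatter, no firm size, and the step that the two limits leave unreadable from compound 1 to compound 3 cannot be read at all. The unmeasured compound 4 `C=CCc1cc(-c2cccc(OC)c2)ccc1O` differs from compound 3 by methoxy in place of methylsulfanyl on an aromatic carbon. Among the measured compounds shown here, no measured step exchanges methylsulfanyl for methoxy, so none bears directly on this change; what the measured compounds show is that the trifluoromethyl analogue, compound 2, reaches only 65900 nM, and the others reach no number at all. Starting from a limit, the step is expected to be a number no higher from compound 3 to compound 4 (the limit leaves the size open), that is, nothing readable beyond the scatter. Compound 4 is therefore estimated at 100000 nM, within 40000 nM to 300000 nM, and most likely reported again as a limit.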

Compound 4, half-maximal inhibitory concentration: > 100000 nM
Compound 4: only a limit was reported; the forecaster's own chance of this, stated with the estimate: 65%; the middle value sits exactly at the limit.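

In this assay compound 4 gives only a limit, so methoxy in place of methylsulfanyl on this aromatic carbon brings no number into reach, and the limit now covers most of the compounds shown: the limit of > 100000 nM in this assay, at which 3 of the 4 values shown sit. The steps from compound 1 and from compound 3 to compound 4 join two limits and cannot be read. Among the compounds shown here, the one readable step is an at least 1.5-fold higher number from compound 2 to compound 4 (0.18 log units; that floor lies within the scatter) and it gives a direction without a firm size, so compound 2 remains the only compound here with a number, with nothing firm separating it from the others.

What these compounds leave open is whether any group at this place brings the shared core clearly under the limit. An amine, a carboxylic acid or a longer chain there could behave differently, and these four compounds cannot say how.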